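This account rests on a few compounds, and the source may have more. Where it says the series, first, only, none or still open, it means among the compounds named here.

Measured so far:
compound 1 `C=CCN1C(=O)C(=O)c2cc(-c3ccc(OC)cc3)ccc21` gives 390 nM
compound 2 `COc1ccc(-c2ccc3c(c2)C(=O)C(=O)N3Cc2ccccc2Cl)cc1` gives 380 nM

For the measured compounds named here, in a functional assay on K562 cells (Homo sapiens) for antiproliferative activity, read by MTT assay, with a stated time of 48 h (on this read-out lower numbers stand for stronger inhibition and higher numbers for weaker inhibition), compound 2 stands level with compound 1, the only other compound measured; the step of a 1.0-fold lower number from compound 1 to compound 2 (0.01 log units; within the scatter) lies within the scatter. Compound 3 `COc1ccc(-c2ccc3c(c2)C(=O)C(=O)N3Cc2cccc(OC)c2)cc1` is the next compound, and its change from compound 2 is 3-methoxyphenyl in place of 2-chlorophenyl on a saturated chain carbon bound to an amide-type nitrogen in a ring. Going by the values given here, the single measured step bears only loosely on this: it exchanged vinyl for 2-chlorophenyl at the same place and moved nothing beyond the scatter. Among the compounds with values here, no measured step exchanges one substituted phenyl for another at this carbon. Compound 3 is therefore expected to show no step beyond the scatter, no change at the digits printed from compound 2 to compound 3 (within the scatter), and an estimated 380 nM with a range from 200 nM to 750 nM.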

Compound 3, half-maximal inhibitory concentration: 680 nM
Compound 3: middle estimate off by 1.8-fold (0.25 log units), on the low side, within the range that was stated.
By their numbers in this assay, from the lowest: compounds 2, 1 and 3 (each within the scatter of the next).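

At the saturated chain carbon bound to an amide-type nitrogen in a ring, a second substituted phenyl can now be compared with the first. In this assay, 3-methoxyphenyl in place of 2-chlorophenyl gives a 1.8-fold higher number from compound 2 to compound 3 (0.25 log units; within the scatter) and 3-methoxyphenyl in place of vinyl gives a 1.7-fold higher number from compound 1 to compound 3 (0.24 log units; within the scatter) so all three groups stand level here. Nothing available explains this level standing. Still open, from the compounds shown here alone, is whether an amine, a carboxylic acid or a longer chain on this carbon would stay level too.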